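The source may report more compounds than this note shows. Statements on the series, on what has been measured and on what is new or still open speak of the compounds shown alone.

Measured compounds in a functional assay on HCT-116 cells (Homo sapiens) for inhibition, read by sulforhodamine B assay, with a stated time of 72 h; on this read-out higher numbers stand for weaker inhibition and lower numbers for stronger inhibition:

- compound 1, `CC(c1ccc(-c2ccccc2)c(F)c1)c1nnc2n1N=C(c1ccc(OC(F)(F)F)cc1)CS2`: 5400 nM
- compound 2, `COc1ccc2cc(C(C)c3nnc4n3N=C(c3ccc(Br)cc3)CS4)ccc2c1`: 11700 nM
- compound 3, `CC(C)Cc1ccc(C(C)c2nnc3n2N=C(c2ccc(Cl)cc2)CS3)cc1`: 6700 nM

Compound 2 carries the highest of the three numbers. Compound 3 sits nearest to it; that gap lies within the scatter, so the two cannot be told apart on this read-out. Compound 1 sits furthest from compound 2, and that gap lies beyond the scatter. Among the measured compounds shown here, no pair among the three differs in a single place, so no step between measured compounds is available to anchor what a single change does on this core.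

Compound 4, `COc1ccc2cc(C(C)c3nnc4n3N=C(c3ccc(F)cc3)CS4)ccc2c1`, has not been measured. It differs from compound 2 in one place: fluoro in place of bromo on an aromatic carbon, on an aromatic carbon of a six-membered aromatic ring of carbon only, para to a large group; cut one bond further out, the difference reads 4-bromophenyl to 4-fluorophenyl. Nothing among the three measured compounds isolates this exchange, so there is no basis for expecting a shift in either direction. The step expected is a 1.1-fold lower number from compound 2 to compound 4 (0.03 log units; within the scatter), that is, none beyond the scatter, with a wide range to reflect the missing anchor.

Compound 4 is expected in this assay at 11000 nM, within 4000 nM to 30000 nM.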

Compound 4, half-maximal inhibitory concentration: 13100 nM
Estimate against measurement, compound 4: 1.2-fold (0.08 log units) below, and the stated range covers the measured number.
By their numbers in this assay, from the lowest: compounds 1, 3, 2 and 4 (each within the scatter of the next, the first and the last beyond it).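

In this assay, among the compounds shown here, the 4-bromophenyl to 4-fluorophenyl exchange gives a 1.1-fold higher number from compound 2 to compound 4 (0.05 log units; within the scatter), the only step on this core that isolates a single place, so bromo and fluoro cannot be told apart here on this read-out. Compound 1 and compound 3 each differ from compound 2 in more than one place, so they could not show what this exchange does alone; with the rest of compound 2 held fixed, it is now seen to leave the number within the scatter. No supporting data on the reason for this result are at hand.

From the compounds shown here alone, whether a group other than these two halogens, such as an amine, a carboxylic acid or a longer chain, would move the number beyond the scatter at this same place stays open on these compounds. Also open, going by these compounds, is whether the bromo to fluoro exchange would give a similar step alongside the other side of the core found in compound 1 or in compound 3.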